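Aryl urea series on the fluorophenoxy-cyclohexyl core

A few compounds are considered here, and "the series" means these few. Any claim that something is new, unique, unknown or untested is made for them only; others in the source may bear on it.

Measured so far:
compound 1 `O=C(Nc1cccc(C(F)(F)F)c1)N[C@H]1CC[C@@H](Oc2ccc(F)cc2)CC1`, 2600 nM
compound 2 `Cc1ccc(NC(=O)N[C@H]2CC[C@H](Oc3ccc(F)cc3)CC2)cc1`, > 20000 nM
compound 3 `O=C(Nc1ccccc1C(=O)O)N[C@H]1CC[C@@H](Oc2ccc(F)cc2)CC1`, > 20000 nM

In a functional assay on CRL2813 cells (Homo sapiens) for cytotoxicity, read by sulforhodamine B assay, with a stated time of 5 days (a higher number here means a weaker inhibitor, a lower number a stronger inhibitor), compound 1 gives 2600 nM. For compound 2 the value > 20000 nM is a limit of this assay, not a number. For compound 3 the value > 20000 nM is likewise a limit. Compound 2 therefore stands at the limit of > 20000 nM in this assay, at which 2 of the 3 values shown sit, with no number of its own.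

Compound 4 `O=C(Nc1ccccc1Cl)N[C@H]1CC[C@H](Oc2ccc(F)cc2)CC1` carries 2-chlorophenyl in place of 4-methylphenyl on an amide-type nitrogen. Going by the values given here, no step between measured compounds covers this change, so its size is unknown from the data; compound 1 shows that an aryl urea on this core can give a number, and compound 4 is expected to move in that direction, if at all, by about an at least 1.4-fold lower number from compound 2 to compound 4 (0.15 log units; that floor lies within the scatter). The estimate for compound 4 in this assay is 14000 nM, within 4000 nM to 40000 nM.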

Compound 4, half-maximal inhibitory concentration: 9100 nM
The estimate for compound 4 lay 1.5-fold (0.19 log units) above the measured number; the measured number falls inside the stated range.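

In this assay, going by these compounds alone, 2-chlorophenyl in place of 4-methylphenyl on an amide-type nitrogen gives an at least 2.1-fold lower number from compound 2 to compound 4 (0.34 log units; beyond the scatter), the only single-place change that can be read so far. It shows that this nitrogen's aryl group alone can bring a compound off the limit of the assay. The true size of the step remains unknown because compound 2 has only a limit: the limit of > 20000 nM in this assay, at which 2 of the 4 values shown sit.

Going by these compounds, it remains open how a 4-chlorophenyl or an aminophenyl group would read at this place. Compound 1 differs from compound 4 in more than one place, so the two cannot be compared.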